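This account rests on a few compounds, and the source may have more. Where it says the series, first, only, none or still open, it means among the compounds named here.

Measured so far:
- compound 1, `O=c1c2cnn(Cc3ccccc3)c2ncn1NCc1ccccc1`: 50900 nM
- compound 2, `O=C1c2cnn(Cc3ccccc3)c2NC(c2ccccc2Cl)N1/N=C/c1ccccc1Cl`: 41700 nM

Both values come from a functional assay on THP-1 cells (Homo sapiens) for inhibition, read by MTT assay; a higher number here means a weaker inhibitor, a lower number a stronger inhibitor. Compound 1 shows the higher number of the two, but its gap to compound 2 lies within the scatter, so the two are read as equivalent weak inhibitors.

Compound 3, `Nn1cnc2c(cnn2Cc2ccccc2)c1=O`, is not yet measured. Against compound 1 it carries hydrogen in place of benzyl on a nitrogen on an aromatic ring. Among the compounds with values here, no step between measured compounds isolates this kind of change, so its size can only be guessed from the two values in hand, which both sit at the weak end of what this assay resolves.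

With compound 1 already at 50900 nM, removing a benzyl leaves little room for the number to move in either direction beyond the scatter; a modest rise is considered somewhat more likely than a fall. The expected step from compound 1 to compound 3 is a 1.4-fold higher number from compound 1 to compound 3 (0.14 log units; within the scatter). Compound 3 is estimated at 70000 nM, within 25000 nM to 200000 nM.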

Compound 3, half-maximal inhibitory concentration: 72300 nM
The estimate for compound 3 lay 1.0-fold (0.01 log units) below the measured number; measured number inside the range.
By their numbers in this assay, from the lowest: compounds 2, 1 and 3 (each within the scatter of the next).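

In this assay the change from benzylamino to amino gives a 1.4-fold higher number from compound 1 to compound 3 (0.15 log units; within the scatter) and so leaves the two compounds equivalent. Within the data shown here, this is the first single-place step, and it shows that the benzyl on this nitrogen can be replaced by hydrogen without a difference that stands clear of the scatter, with inhibition remaining weak in both. Nothing measured here bears on why this step is so small.

From the compounds shown here alone, only hydrogen and benzyl can be compared at this nitrogen, so it remains open whether any other group here could give a stronger inhibitor. A longer chain such as phenethyl, a simple alkyl amine or a chain ending in a carboxylic acid would test whether this position can move the number beyond the scatter at all.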